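Cyclopropyl for Methyl: A Small Change at the Amine

The source may report more compounds than this note shows. Statements on the series, on what has been measured and on what is new or still open speak of the compounds shown alone.

Measured compounds:
- Compound 1 `CNc1nc(NCc2ccc(NC(=O)c3ccncc3)cc2)c2ccccc2n1`: in a functional assay on SW480 cells (Homo sapiens) for inhibition, read by luminescence and resazurin assay, with a stated time of 3 days (a lower number here means a stronger inhibitor, a higher number a weaker inhibitor), compound 1 gives > 20000 nM, which is a limit of the assay and not a number.
- Compound 2 `CNc1nc(NCc2ccc(NS(=O)(=O)c3ccc(F)cc3)cc2)c2ccccc2n1`: in this assay compound 2 gives 4800 nM.
- Compound 3 `CNc1nc(NCc2ccc(NC(=O)c3ccc(F)cc3)cc2)c2ccccc2n1`: in this assay compound 3 gives 2000 nM.

Among the two numbers that are not limits, compound 2 stands highest; its nearest neighbour is compound 3, reached by the step of a 2.4-fold lower number from compound 2 to compound 3 (0.38 log units; beyond the scatter). Among the measured compounds shown here, the other steps, an at least 4.1-fold lower number from compound 1 to compound 2 (0.61 log units; beyond the scatter) and an at least 10-fold lower number from compound 1 to compound 3 (1.00 log units; beyond the scatter), start from a limit of > 20000 nM in this assay, at which 1 of the 3 values shown sits, and say only that the change at the amide or sulfonamide end matters.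

Compound 4 `O=S(=O)(Nc1ccc(CNc2nc(NC3CC3)nc3ccccc23)cc1)c1ccc(F)cc1` differs from compound 2 in one place: cyclopropyl in place of methyl on a nitrogen on an aromatic ring. For the measured compounds named here, none of the measured steps touches this part of the molecule; all three concern the group on the nitrogen at the far end of the shared core. Going by the values given here, there is therefore no measured step that bears on this change, and no step beyond the scatter is expected in this assay.

The estimate for compound 4 is 4000 nM, between 1500 nM and 12000 nM. This estimate means the step of a 1.2-fold lower number from compound 2 to compound 4 (0.08 log units; within the scatter), which is expected to sit within the scatter.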

Compound 4, half-maximal inhibitory concentration: 4100 nM
The estimate for compound 4 lay 1.0-fold (0.01 log units) below the measured number; low and high end bracket the measured number.
By their numbers in this assay, from the lowest: compound 3; then compounds 4 and 2 (each within the scatter of the next). At a limit, above all of these: compound 1.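

Replacing methyl with cyclopropyl on this nitrogen gives a 1.2-fold lower number from compound 2 to compound 4 (0.07 log units; within the scatter) in this assay, so compound 2 and compound 4 cannot be told apart in this assay. Among the compounds shown here, this is the first reading at the methylamino end of the shared core, since every earlier step concerned the group at the far end, and it shows that here a group of 3 heavy atoms with a three-membered ring can stand in place of a single methyl carbon without a measurable change in the number. Nothing measured here explains why the number stays within the scatter, and this single pair sets no rule for the position.

Open, from the compounds shown here alone, is whether the same change behaves alike on the amide of compound 3, which gives 2000 nM, since this step is read only on the sulfonamide series. Also open, going by these compounds, is how the position responds to groups of a different kind, such as a longer chain like n-butyl, or a chain that ends in an alcohol, an amine or a carboxylic acid.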